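This account rests on a few compounds, and the source may have more. Where it says the series, first, only, none or still open, it means among the compounds named here.

Measured so far in an ADME assay on BHK-21 cells (Mesocricetus auratus) for cytotoxicity, read by MTT assay, with a stated time of 72 h; a lower number here means that less compound is tolerated, a higher number that more compound is tolerated:
- compound 1 `NS(=O)(=O)c1ccc(N2N=C(c3ccc(OCc4ccccc4)cc3)CC2c2ccc(F)cc2)cc1` gives 60000 nM
- compound 2 `Cc1cccc(C2CC(c3ccc(Oc4ccccc4)cc3)=NN2c2ccc(S(N)(=O)=O)cc2)c1` gives 8000 nM
- compound 3 `NS(=O)(=O)c1ccc(N2N=C(c3ccc(OCc4ccccc4)cc3)CC2c2ccccc2F)cc1` gives 90000 nM

Compound 3 at 90000 nM sits within the scatter of compound 1 and well clear of compound 2. Compound 4 `Cc1cccc(C2CC(c3ccc(OCc4ccccc4)cc3)=NN2c2ccc(S(N)(=O)=O)cc2)c1`, not yet measured, has 3-methylphenyl in place of 2-fluorophenyl on a saturated ring carbon. Within the data shown here, the one measured step at this carbon is a 1.5-fold higher number from compound 1 to compound 3 (0.18 log units; within the scatter), which gives little reason to expect a large move. Compound 2 carries the same 3-methylphenyl at 8000 nM but also differs from compound 4 elsewhere, so it only pulls the expectation modestly downward in this assay. The expected step is a 2.0-fold lower number from compound 3 to compound 4 (0.30 log units; within the scatter). Compound 4 is estimated at 45000 nM, with an expected range of 12000 nM to 110000 nM.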

Compound 4, half-maximal cytotoxic concentration: 8000 nM
Estimate against measurement, compound 4: 5.6-fold (0.75 log units) above; the whole stated range lies above it.
By their numbers in this assay, from the lowest: compounds 2 and 4 (each within the scatter of the next); then compounds 1 and 3 (each within the scatter of the next).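

In this assay, an 11-fold lower number from compound 3 to compound 4 (1.05 log units; beyond the scatter) and a 7.5-fold lower number from compound 1 to compound 4 (0.88 log units; beyond the scatter) show that this saturated ring carbon can move the number once 3-methylphenyl enters, whereas a 1.5-fold higher number from compound 1 to compound 3 (0.18 log units; within the scatter) is all that the fluorophenyl swap gave. With 3-methylphenyl in place, no change at the digits printed from compound 2 to compound 4 (within the scatter) comes with benzyl in place of phenyl on the oxygen, so that change does not register between these two compounds. No measured evidence accounts for the drop.

The compounds shown leave open whether the methyl group itself or its ring placement carries the step. A 4-methylphenyl or 3-fluorophenyl group on this carbon would separate the two.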